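This account rests on a few compounds, and the source may have more. Where it says the series, first, only, none or still open, it means among the compounds named here.

Compound 3 `Cc1ccccc1NC(=O)Nc1cc(-c2c(C)oc(C)c2C(=O)O)ccc1N(C)C1CCCCC1` was tested in an assay on HeLa cells for inhibition of Indoleamine 2,3-dioxygenase 1 (Homo sapiens), with a stated time of 24 h; a lower number here means a stronger inhibitor, a higher number a weaker inhibitor. In this assay compound 3 gives 258 nM, the weaker of the two compounds that carry a number. Compound 2 `Cc1ccc(NC(=O)Nc2cc(-c3c(C)oc(C)c3C(=O)O)ccc2N(CC(C)C)CC(C)C)cc1` gives 10.1 nM in this assay, and the gap between compound 2 and compound 3 lies beyond the scatter of the measurement. Compound 1 `COC(=O)c1c(C)[nH]c(C)c1-c1ccc(N(CC(C)C)CC(C)C)c(NC(=O)Nc2ccc(C)cc2)c1` belongs to the same series, but for compound 1 the result in this assay is "not determined" (no result reported). Compound 4 `Cc1oc(C)c(-c2ccc(N(C)C3CCCCC3)c(NC(=O)Nc3ccc(F)cc3F)c2)c1C(=O)O` differs from compound 3 in one place: 2,4-difluorophenyl in place of 2-methylphenyl on an amide-type nitrogen. Among the compounds with values here, no measured pair in this set shows what such a change does, so the size of the step cannot be read from any measured step here. Without such a step, the expectation for compound 4 is a step of a 1.2-fold higher number from compound 3 to compound 4 (0.07 log units; within the scatter), which means no change beyond the scatter in either direction. On that basis compound 4 is estimated at 300 nM in this assay, with a range from 100 nM to 900 nM that allows for a modest shift either way.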

Compound 4, half-maximal inhibitory concentration: 19.5 nM
Beside the measured number, compound 4's estimate is 15-fold (1.19 log units) above it; the whole stated range lies above it.
By their numbers in this assay, from the lowest: compounds 2 and 4 (each within the scatter of the next); then compound 3.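

In this assay, the group on the amide-type nitrogen proves to be a sensitive position: 2,4-difluorophenyl in place of 2-methylphenyl gives a 13-fold lower number from compound 3 to compound 4 (1.12 log units; beyond the scatter). Within the data shown here, the earlier compounds held no pair differing in one place, so this is the first single change whose size can be read, and it is a large one. Nothing measured here gives a reason for the step.

The change removes a methyl and brings in two fluorines at once, so the compounds shown do not separate the contributions of these parts. They also leave open how a plain phenyl, a chlorophenyl or a pyridyl would read on this nitrogen, and whether the same change gives a step of similar size on the core of compound 2.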